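A methoxy added to the anilide ring of compound 3

The source may hold more compounds than are shown below. What is called first, only, known or untested is meant among the compounds shown, and "the series" means these compounds.

compound 1 `COc1ccc(NC(=O)n2nc(-c3sc(NC(=O)C(C)(C)C)nc3C)cc2Cc2cc(Cl)ccc2OC)cc1` gives 1000 nM in an assay on cells with Cystic fibrosis transmembrane conductance regulator variant F508del (Homo sapiens) as the target, read by fluorescence, with stated times of 24 h and 30 min; a lower number here means that less compound is needed, a higher number that more compound is needed for the effect
compound 2 `CN(C)CCN1CCN(c2nc(-c3ccccn3)nc3c2CN(Cc2ccc(F)cc2)CC3)CC1` gives 100000 nM
compound 3 `C=CCc1cc(-c2sc(NC(=O)C(C)(C)C)nc2C)nn1C(=O)Nc1ccccc1` gives 3020 nM

Among the three numbers compound 3 stands second highest. It lies nearest to compound 1, whose lower number still sits beyond the usual scatter, and farthest from compound 2, whose much higher number also lies beyond it. Compound 4 `C=CCc1cc(-c2sc(NC(=O)C(C)(C)C)nc2C)nn1C(=O)Nc1ccc(OC)cc1` keeps the core of compound 3 and differs in one place: methoxy in place of hydrogen on an aromatic carbon. For the measured compounds named here, no pair of measured compounds differs in this single way, so no measured step guides the expectation. Going by the values given here, compound 1 also carries a methoxy on its anilide ring, but it differs from compound 3 in other places too, so the values of compound 1 and compound 3 show only that the two compounds stand apart by more than the scatter. For compound 4 a small step downward, at the edge of the scatter, is expected: a 1.5-fold lower number from compound 3 to compound 4 (0.18 log units; within the scatter). The estimate for compound 4 is 2000 nM, expected to fall between 700 nM and 6000 nM.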

Compound 4, half-maximal effective concentration: 933 nM
The estimate for compound 4 lay 2.1-fold (0.33 log units) above the measured number; measured number inside the range.
By their numbers in this assay, from the lowest: compounds 4 and 1 (each within the scatter of the next); then compound 3; then compound 2.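

Read in this assay, the change from phenyl to 4-methoxyphenyl gives a 3.2-fold lower number from compound 3 to compound 4 (0.51 log units; beyond the scatter) and is the first single-place reading at this aromatic carbon, para to a large group. The step lies beyond the scatter, so this position is not indifferent to what it carries, at least when hydrogen gives way to methoxy. With the methoxy in place, vinyl in place of 5-chloro-2-methoxyphenyl on a saturated chain carbon bound to an aromatic carbon gives a 1.1-fold lower number from compound 1 to compound 4 (0.03 log units; within the scatter) and stays within the scatter, so that exchange shows no measurable difference in this pair.

The compounds shown leave open whether another group at this place, such as an amine, a carboxylic acid or a longer ethoxy chain, would move the number as methoxy does. No measurement shown here accounts for the step.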